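This account rests on a few compounds, and the source may have more. Where it says the series, first, only, none or still open, it means among the compounds named here.

Measured in an ADME assay on MT4 cells (Homo sapiens) for cytotoxicity, read by MTT assay, with a stated time of 5 days; a higher number here means that more compound is tolerated, a lower number that less compound is tolerated: compound 1 `CC(C)=CCN1C(=O)N(Cc2ccccc2)S(=O)(=O)n2cccc21` gives 226000 nM. Compound 2 `N#Cc1ccccc1CN1C(=O)N(Cc2cccc(F)c2)S(=O)(=O)n2cccc21` reaches only a limit, > 305000 nM. Compound 3 `N#Cc1ccccc1CN1C(=O)N(Cc2cccc(Cl)c2)S(=O)(=O)n2cccc21` also reaches only a limit, > 293000 nM.

Compound 2 thus stands at a limit in this assay, and one of the other two values shown is likewise a limit. Within the data shown here, the single measured step, a step that the two limits leave unreadable from compound 2 to compound 3, is chloro in place of fluoro on an aromatic carbon and cannot be read between the limit of > 305000 nM in this assay, at which 1 of the 3 values shown sits, and (the limit of > 293000 nM in this assay, at which 1 of the 3 values shown sits). Compound 4 `O=C1N(Cc2ccccc2Br)c2cccn2S(=O)(=O)N1Cc1cccc(F)c1` differs from compound 2 by bromo in place of cyano on an aromatic carbon. Among the measured compounds shown here, no measured step bears on this change, so compound 4 is expected to show an at least 1.0-fold lower number from compound 2 to compound 4 (0.03 log units; that floor lies within the scatter), nothing beyond the scatter. Compound 4 is estimated at 280000 nM, within 120000 nM to 450000 nM, quite possibly again only a limit.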

Compound 4, half-maximal cytotoxic concentration: > 269000 nM
Compound 4 was reported as a limit (the forecaster's own chance of this, stated with the estimate: 60%); the middle value is on the limit's open side.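

Among these compounds, compound 4 gives only a limit, > 269000 nM; compound 2 also stands at a limit, so no step from compound 2 to compound 4 can be read. The compounds shown leave open whether bromo in place of cyano changes the number in this assay at all.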